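The compounds below may be only part of what the source reports. "The series", "measured", "known", "first", "only" and "open" are said of these compounds alone.

Compound 2, `N#CC1=C(N)Oc2c(N)cc3nc4ccccc4nc3c2C12C(=O)N(Cc1cnnn1-c1ccc([N+](=O)[O-])cc1)c1ccccc12`, shows no measurable inhibition in a functional assay on HCT-116 cells (Homo sapiens) for antiproliferative activity, read by MTT assay, with a stated time of 48 h; a lower number here means a stronger inhibitor, a higher number a weaker inhibitor: in this assay compound 2 gives > 50000 nM, which is a limit of the assay rather than a number. Compound 1, `CCOc1ccccc1-n1nncc1CN1C(=O)C2(C(C#N)=C(N)Oc3c(N)cc4nc5ccccc5nc4c32)c2ccccc21`, differs from it only in the group on the aromatic nitrogen; in this assay compound 1 likewise gives > 50000 nM, again a limit. The step between the two is therefore a step that the two limits leave unreadable from compound 1 to compound 2, and the limit of > 50000 nM in this assay, at which 2 of the 2 values shown sit, is the whole of the evidence at hand. Compound 3, `CCc1cccc(C)c1-n1nncc1CN1C(=O)C2(C(C#N)=C(N)Oc3c(N)cc4nc5ccccc5nc4c32)c2ccccc21`, arises from compound 2 by the change (2-ethyl-6-methylphenyl in place of 4-nitrophenyl on an aromatic nitrogen). Going by the values given here, the only measured step at this position, a step that the two limits leave unreadable from compound 1 to compound 2, cannot be sized, so no direction can be taken from it; with both measured compounds sitting at the limit, compound 3 is expected to stay there too, and the step that the limit leaves unreadable from compound 2 to compound 3 is expected to be indistinguishable from none. Compound 3 is thus estimated at 60000 nM, within 20000 nM to 200000 nM.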

Compound 3, half-maximal inhibitory concentration: > 50000 nM
Compound 3: only a limit was reported; the forecaster's own chance of this, stated with the estimate: 80%; the middle value does not contradict the limit.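

In this assay compound 3 gives > 50000 nM, which is a limit and not a number. The steps linking compound 1, compound 2 and compound 3 cannot be read. The compounds shown leave open whether any of these three groups on the aromatic nitrogen differs from the others in this read-out: the limit of > 50000 nM in this assay, at which 3 of the 3 values shown sit.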